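Azole swap on the heterocyclic methyl arm: oxazole to thiazole

The compounds below may be only part of what the source reports. "The series", "measured", "known", "first", "only" and "open" are said of these compounds alone.

Compound 1 `Cc1noc(C)c1-c1ccc2c(c1)C(c1ccccc1)N(Cc1ncc(-c3ccccc3)o1)C(=O)N2C` carries a (5-phenyl-1,3-oxazol-2-yl)methyl arm on a ring amide-type nitrogen of its shared core. In a functional assay on MCF7 cells (Homo sapiens) for inhibition, read by MTT assay, with a stated time of 48 h, tested at 2 uM (a lower number here means less inhibition, a higher number more inhibition at the concentration tested (going by the name of the read-out)), compound 1 gives 34%, and compound 2 `Cc1noc(C)c1-c1ccc2c(c1)C(c1ccccc1)N(Cc1nnc(-c3ccccc3)s1)C(=O)N2C` gives 35.7%; the two numbers lie within the scatter of each other, so neither can be placed apart from the other. Among the compounds with values here, the single measured step, a number 1.7 percentage points higher from compound 1 to compound 2 (within the scatter), exchanges one five-membered aromatic ring bearing two hetero atoms for another and leaves the read-out essentially unmoved. Compound 3 `Cc1noc(C)c1-c1ccc2c(c1)C(c1ccccc1)N(Cc1nc(-c3ccccc3)cs1)C(=O)N2C` makes a change of the same kind: 4-phenyl-1,3-thiazol-2-yl in place of 5-phenyl-1,3-oxazol-2-yl on a saturated chain carbon bound to an amide-type nitrogen in a ring. Within the data shown here, since the one comparable step stays within the scatter, no shift beyond the scatter is expected in this assay for compound 3, whose step from compound 1 is estimated at a number 1 percentage points higher from compound 1 to compound 3 (within the scatter). Compound 3 is therefore expected to give 35%, within a range from 22% to 48%.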

Compound 3, a percentage reported as inhibition, at one concentration (the size of the read-out at that concentration, not a potency): 29.1%
The estimate for compound 3 lay 5.9 percentage points above the measured number, within the range that was stated.
By their numbers in this assay, from the lowest: compounds 3, 1 and 2 (each within the scatter of the next).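

In this assay, 4-phenyl-1,3-thiazol-2-yl in place of 5-phenyl-1,3-oxazol-2-yl gives a number 4.9 percentage points lower from compound 1 to compound 3 (within the scatter), and the same group in place of 5-phenyl-1,3,4-thiadiazol-2-yl gives a number 6.6 percentage points lower from compound 2 to compound 3 (within the scatter). On a saturated chain carbon bound to an amide-type nitrogen in a ring, three different phenyl-bearing azoles now stand within the scatter of one another, including one whose name carries the phenyl at the 4 rather than the 5 position, so neither the ring exchange nor that shift separates the compounds here. Nothing measured explains this flat result.

Open, from the compounds shown here alone, is whether an amine or a carboxylic acid in place of the phenyl-bearing azole, or a longer chain in place of the methyl link, would move the read-out beyond the scatter. Also open, going by these compounds, is whether the three compounds would stay together at other concentrations, since a single-concentration read-out is not a potency.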